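A few compounds are considered here, and "the series" means these few. Any claim that something is new, unique, unknown or untested is made for them only; others in the source may bear on it.

Of the compounds shown here, three sharing one core have been measured in a functional assay on HepG2 cells (Homo sapiens) for cytotoxicity, read by MTT assay, with a stated time of 48 h; a higher number here means a weaker inhibitor, a lower number a stronger inhibitor. Compound 1 `CC(C)=CCC/C(C)=C/CC/C(C)=C/CC[C@@H]1[C@@]2(C)CCC(=O)C(C)(C)[C@@H]2CC[C@@]1(C)O` bears a ketone on that core, and in this assay compound 1 gives 26600 nM. Compound 2 `CC(C)=CCC/C(C)=C/CC/C(C)=C/CC[C@@H]1[C@@]2(C)CC/C(=N\OCc3cn(-c4ccc(F)cc4)nn3)C(C)(C)[C@@H]2CC[C@@]1(C)O` carries instead an oxime ether leading to a triazole with 4-fluorophenyl on an aromatic nitrogen; in this assay compound 2 gives 63100 nM. Compound 3 `CC(C)=CCC/C(C)=C/CC/C(C)=C/CC[C@@H]1[C@@]2(C)CC/C(=N\OCc3cn(-c4ccccc4C#N)nn3)C(C)(C)[C@@H]2CC[C@@]1(C)O` has 2-cyanophenyl on that aromatic nitrogen, and in this assay compound 3 gives 21900 nM. For the measured compounds named here, the one measured change of the aryl group is a 2.9-fold lower number from compound 2 to compound 3 (0.46 log units; beyond the scatter). Compound 3 and compound 1 give numbers within the scatter of each other, while compound 2 stands apart beyond the scatter.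

Compound 4 `CC(C)=CCC/C(C)=C/CC/C(C)=C/CC[C@@H]1[C@@]2(C)CC/C(=N\OCc3cn(-c4ccncc4)nn3)C(C)(C)[C@@H]2CC[C@@]1(C)O` differs from compound 3 by pyridin-4-yl in place of 2-cyanophenyl on an aromatic nitrogen. Going by the values given here, the only step that bears on this change swapped one aryl group for another and was modest; the new group is of a different kind, so no direction beyond the scatter can be read from it. Compound 4 is therefore expected to give 30000 nM, within 12000 nM to 80000 nM. That estimate means an expected step of a 1.4-fold higher number from compound 3 to compound 4 (0.14 log units; within the scatter), within the scatter.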

Compound 4, half-maximal inhibitory concentration: 22000 nM
Compound 4: middle estimate off by 1.4-fold (0.13 log units), on the high side; the range from low to high includes it.
By their numbers in this assay, from the lowest: compounds 3, 4 and 1 (each within the scatter of the next); then compound 2.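

In this assay the swap of 2-cyanophenyl for pyridin-4-yl on the aromatic nitrogen of the triazole gives a 1.0-fold higher number from compound 3 to compound 4 (0.00 log units; within the scatter), so two quite different aryl groups, one a carbon-only ring with a nitrile and the other a ring with a hetero atom, cannot be told apart at this position. Set against 4-fluorophenyl, pyridin-4-yl gives a 2.9-fold lower number from compound 2 to compound 4 (0.46 log units; beyond the scatter), which repeats the size of the earlier step and leaves compound 2 as the only one of the three triazole compounds that stands apart. No measurement offered here accounts for this separation.

The compounds shown leave open whether an aryl ring bearing an amine or a carboxylic acid would stay with compound 3 and compound 4 or move away from them. From the compounds shown here alone, it is also open how a longer alkyl chain in place of the aryl ring on that nitrogen would read in this assay.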